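Swapping phenyl for aminopyridyl in a nitroimidazole-oxadiazole series

The source may report more compounds than this note shows. Statements on the series, on what has been measured and on what is new or still open speak of the compounds shown alone.

Measured compounds:
compound 1 `Cc1ncc([N+](=O)[O-])n1CCSc1nnc(-c2ccccc2)o1`: 20500 nM
compound 2 `Cc1ncc([N+](=O)[O-])n1CCSc1nnc(-c2ccc(N)cc2)o1`: 19800 nM
compound 3 `Cc1ncc([N+](=O)[O-])n1CCSc1nnc(-c2ccccc2Cl)o1`: 22500 nM

In a functional assay on MCF7 cells (Homo sapiens) for cytotoxicity, read by MTT assay, with a stated time of 48 h (a lower number here means a stronger inhibitor, a higher number a weaker inhibitor), compound 1 sits among three numbers that all lie within the usual scatter of one another, as the steps of a 1.0-fold lower number from compound 1 to compound 2 (0.02 log units; within the scatter) and a 1.1-fold higher number from compound 1 to compound 3 (0.04 log units; within the scatter) show. Compound 4 `Cc1ncc([N+](=O)[O-])n1CCSc1nnc(-c2cnccc2N)o1` differs from compound 1 by 4-aminopyridin-3-yl in place of phenyl on an aromatic carbon. Within the data shown here, the steps that bear on it are those two, each a change on the same aromatic ring and each within the scatter, so no step beyond the scatter is expected in this assay for compound 4 either, in neither direction. The estimate for compound 4 is 20000 nM, with a range from 8000 nM to 50000 nM, which would mean an expected step of a 1.0-fold lower number from compound 1 to compound 4 (0.01 log units; within the scatter).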

Compound 4, half-maximal inhibitory concentration: 29300 nM
Beside the measured number, compound 4's estimate is 1.5-fold (0.17 log units) below it, and the stated range covers the measured number.
By their numbers in this assay, from the lowest: compounds 2, 1, 3 and 4 (each within the scatter of the next).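

In this assay, a ring carrying a ring nitrogen and an amino group can replace phenyl: 4-aminopyridin-3-yl gives a 1.4-fold higher number from compound 1 to compound 4 (0.16 log units; within the scatter). Its steps from the other two aryl compounds are also small, a 1.3-fold higher number from compound 3 to compound 4 (0.11 log units; within the scatter) and a 1.5-fold higher number from compound 2 to compound 4 (0.17 log units; within the scatter), so among these four compounds, a hetero atom in the ring does not separate one compound from another at this position. No supporting measurement bears on this result. Going by these compounds, whether a non-aromatic group here, such as morpholine, or a carboxylic acid on the ring, would give a step beyond the scatter stays open.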